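Compound 4: a methyl added to the chain of compound 3

The source may hold more compounds than are shown below. What is called first, only, known or untested is meant among the compounds shown, and "the series" means these compounds.

Measured compounds, read in a functional assay on the whole organism (Tail, strain ICR) with Mus musculus as the target, in the tail flick test, with a stated time of 60 min, at a dose of 25 umol/kg by the oral route; on this read-out higher numbers stand for a stronger effect at the one dose given and lower numbers for a weaker effect:
compound 1, `N=C(N)NCCC[C@H](NC(=O)CN(c1ncnc2c1ncn2C1CCCCO1)C1CC1)C(=O)OCc1ccccc1`, gives 52.4%.
compound 2, `CC[C@H](C)[C@H](NC(=O)CN(c1nc(Cl)nc2[nH]cnc12)C1CC1)C(=O)OCc1ccccc1`, gives 40.6%.
compound 3, `CC(C)[C@H](NC(=O)CN(c1ncnc2c1ncn2C1CCCCO1)C1CC1)C(=O)OCc1ccccc1`, gives 34.9%.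

Compound 3 holds the lowest of the three numbers in this assay. Its nearest neighbour is compound 2, whose number lies within the scatter of that of compound 3, so no order between the two can be read. The gap to compound 1 is beyond the scatter: a number 17.5 percentage points lower from compound 1 to compound 3 (beyond the scatter).

Compound 4, `CC[C@H](C)[C@H](NC(=O)CN(c1ncnc2c1ncn2C1CCCCO1)C1CC1)C(=O)OCc1ccccc1`, is not yet measured. It differs from compound 3 by methyl in place of hydrogen on a saturated chain carbon, three bonds along the chain from an amide-type nitrogen and a carbonyl carbon. Among the compounds with values here, the one measured step, from compound 1 to compound 3, concerns a different exchange and says nothing direct about the addition of a methyl. Compound 2 carries the sec-butyl group of compound 4 on a different core; its value and that of compound 3 sit within the scatter of one another, and this is the only pointer available. No step beyond the scatter is therefore expected in this assay; the change from compound 3 to compound 4 is estimated at a number 5.1 percentage points higher from compound 3 to compound 4 (within the scatter). Compound 4 is expected to give 40% in this assay, with a range from 27% to 52%.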

Compound 4, a percentage reported as activity, at one dose (the size of the read-out at that dose, not a potency): 27.4%
The estimate for compound 4 lay 12.6 percentage points above the measured number, within the range that was stated.
By their numbers in this assay, from the lowest: compounds 4, 3 and 2 (each within the scatter of the next, the first and the last beyond it); then compound 1.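

Isopropyl to sec-butyl on this saturated chain carbon is the first exchange in the series confined to a single added methyl, and in this assay it gives a step within the scatter (a number 7.5 percentage points lower from compound 3 to compound 4 (within the scatter)), so no order can be read between the two compounds. With sec-butyl in place, the group of compound 1 again separates from a carbon-only group at this position (a number 25 percentage points lower from compound 1 to compound 4 (beyond the scatter)), as it did with isopropyl (a number 17.5 percentage points lower from compound 1 to compound 3 (beyond the scatter)), so the gap now holds for two carbon-only groups on the shared core, though not for any other kind of group. No measurement at hand accounts for either gap.

As far as these compounds go, whether an amine or a carboxylic acid on a chain of this kind would match compound 1 remains open, and so does whether a longer unbranched chain would stay with the carbon-only groups. Within the data shown here, it is also open whether the methyl exchange would read the same way on another core, since the one step available for it rests on a single pair of compounds at one dose.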